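The source may report more compounds than this note shows. Statements on the series, on what has been measured and on what is new or still open speak of the compounds shown alone.

The series shares the core shown for compound 1 `O=c1[nH]/c(=N\OCCCc2cccc(F)c2)ccn1[C@@H]1O[C@H](COP(=O)(O)OP(=O)(O)OP(=O)(O)O)[C@@H](O)[C@H]1O`, and differs in the group on a saturated chain carbon, three bonds along the chain from an oxygen. In a functional assay on 1321-N1 cells for agonist activity at P2Y purinoceptor 2 (Homo sapiens), read by scintillation counting and inositol phosphate accumulation (on this read-out lower numbers stand for an effect already at smaller amounts and higher numbers for an effect only at larger amounts of compound), compound 1 gives 190 nM. Compound 2 `O=c1[nH]/c(=N\OCCCc2ccc(I)cc2)ccn1[C@@H]1O[C@H](COP(=O)(O)OP(=O)(O)OP(=O)(O)O)[C@@H](O)[C@H]1O` carries 4-iodophenyl there; in this assay compound 2 gives 187 nM, which is a 1.0-fold lower number from compound 1 to compound 2 (0.01 log units; within the scatter). On these two numbers compound 2 stands level with compound 1, and neither can be told from the other. Compound 3 `O=c1[nH]/c(=N\OCCCc2ccc3ccccc3c2)ccn1[C@@H]1O[C@H](COP(=O)(O)OP(=O)(O)OP(=O)(O)O)[C@@H](O)[C@H]1O` takes the next step: naphthalen-2-yl in place of 4-iodophenyl on a saturated chain carbon, three bonds along the chain from an oxygen. Among the compounds with values here, the only measured step that bears on an exchange of this group is the one from compound 1 to compound 2, and it showed no movement. For compound 3 no step beyond the scatter in this assay is therefore expected, a 1.0-fold lower number from compound 2 to compound 3 (0.02 log units; within the scatter). The estimate for compound 3 in this assay is 180 nM, with a range of 60 nM to 550 nM.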

Compound 3, half-maximal effective concentration: 139 nM
The estimate for compound 3 lay 1.3-fold (0.11 log units) above the measured number; low and high end bracket the measured number.
By their numbers in this assay, from the lowest: compounds 3, 2 and 1 (each within the scatter of the next).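

In this assay the position also accepts naphthalen-2-yl, with 2 six-membered aromatic rings of carbon only in place of one, and the number stays within the scatter: a 1.3-fold lower number from compound 2 to compound 3 (0.13 log units; within the scatter), and a 1.4-fold lower number from compound 1 to compound 3 (0.14 log units; within the scatter). The three groups shown, 3-fluorophenyl, 4-iodophenyl and naphthalen-2-yl, therefore cannot be told apart on this read-out, and no exchange at this position has yet produced a step beyond the scatter. Nothing at hand explains why these groups stand level.

On these data alone, what an amine or a carboxylic acid in place of these aromatic groups would do remains open. Also open, as far as these compounds go, is whether a longer chain carrying the same aromatic groups would stay at this level in this assay.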